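A few compounds are considered here, and "the series" means these few. Any claim that something is new, unique, unknown or untested is made for them only; others in the source may bear on it.

Among the measured compounds shown here, compound 2 `COc1cc(C(=O)NS(=O)(=O)c2ccccc2C)ccc1Cc1cn(C=O)c2ccc(NC(=O)OC3CCCC3)cc12` stands at the level of its one neighbour: in an assay on isolated protein for binding affinity to cysteinyl leukotriene receptor 1 (Cavia porcellus) (on this read-out lower numbers stand for stronger inhibition and higher numbers for weaker inhibition), compound 2 gives 1 nM, and compound 1 `COc1cc(C(=O)NS(=O)(=O)c2ccccc2C)ccc1Cc1cn(C(F)F)c2ccc(NC(=O)OC3CCCC3)cc12` gives 1 nM in this assay. For the measured compounds named here, the only step within the data, no change at the digits printed from compound 1 to compound 2 (within the scatter), shows that exchanging one substituent on the aromatic nitrogen for another left the read-out where it was. The change that leads to compound 3 `COc1cc(C(=O)NS(=O)(=O)c2ccccc2C)ccc1Cc1c[nH]c2ccc(NC(=O)OC3CCCC3)cc12` is hydrogen in place of formyl on an aromatic nitrogen; here the nitrogen is left bare rather than carrying a different group, so the measured step touches the same position but not the same kind of exchange. With nothing else to go on, the step of no change at the digits printed from compound 1 to compound 2 (within the scatter) is the best guide, and a change of about the same size, none beyond the scatter, is expected, which is what a 1.5-fold higher number from compound 2 to compound 3 (0.18 log units; within the scatter) means. Compound 3 is therefore estimated at 1.5 nM in this assay, with a range from 0.4 nM to 6 nM.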

Compound 3, half-maximal inhibitory concentration: 1 nM
The estimate for compound 3 lay 1.5-fold (0.18 log units) above the measured number, within the range that was stated.
By their numbers in this assay, from the lowest: compounds 1, 2 and 3 (each within the scatter of the next).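

In this assay the read-out shows no change at the digits printed from compound 2 to compound 3 (within the scatter) and likewise no change at the digits printed from compound 1 to compound 3 (within the scatter) once the nitrogen is left bare. The earlier pair only swapped one group for another, whereas these steps show that the aromatic nitrogen of the five-membered ring can carry hydrogen alone, with neither formyl nor difluoromethyl on it, and the read-out still stays level. Nothing measured here accounts for this insensitivity.

The compounds shown leave open whether a longer chain, an amine or a carboxylic acid on this nitrogen would also leave the read-out level. Since all three compounds stand level, they also leave open which kind of group at this position, if any, would shift it beyond the scatter.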